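A few compounds are considered here, and "the series" means these few. Any claim that something is new, unique, unknown or untested is made for them only; others in the source may bear on it.

Measured compounds:
Compound 1, `Cc1cc(C#N)nc(NNC(=O)Nc2cc(Cl)nc(Cl)c2)c1`, in a functional assay on CHO cells for agonist activity at sphingosine 1-phosphate receptor 2 (Homo sapiens), read by fluorescence and calcium flux, with a stated time of 3 min (a higher number here means a weaker inhibitor, a lower number a stronger inhibitor), gives only a limit, > 23000 nM.
Compound 2, `CCOC(=O)c1cc(C)cc(NNC(=O)Nc2cc(Cl)nc(Cl)c2)n1`, in this assay likewise gives only a limit, > 23000 nM.
Compound 3, `Cc1cc(NNC(=O)Nc2cc(Cl)nc(Cl)c2)ncc1-c1cnn(C)c1`, in this assay also gives only a limit, > 23000 nM.

None of the three measured compounds therefore has a numerical value in this assay; each sits at the same limit, and compound 3 stands where the other two stand, with nothing to set it apart. For the measured compounds named here, the only comparable pair among them, compound 1 and compound 2, shows a step that the two limits leave unreadable from compound 1 to compound 2, so that exchange of ethoxycarbonyl for cyano on an aromatic carbon tells nothing about direction or size.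

Compound 4, `Cc1cc(NNC(=O)Nc2cc(Cl)nc(Cl)c2)ncc1-c1cn(C)nc1C`, differs from compound 3 by methyl in place of hydrogen on an aromatic carbon. Going by the values given here, no measured step bears on such a change, and the whole picture is the limit of > 23000 nM in this assay, at which 3 of the 3 values shown sit. Among the compounds with values here, a step from compound 3 to compound 4 is therefore expected to be a step that the limit leaves unreadable from compound 3 to compound 4, that is, no step at all beyond the scatter. Compound 4 is estimated at 30000 nM, most likely again only a limit, within 15000 nM to 100000 nM.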

Compound 4, half-maximal inhibitory concentration: > 23000 nM
Compound 4 ended at the assay's limit; the forecaster's own chance of this, stated with the estimate: 85%; the middle value does not contradict the limit.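

In this assay compound 4 gives > 23000 nM which is only a limit. For the compounds shown here, compound 3 and compound 4 both stand at limits, so no step between them can be read. The compounds shown leave open whether any change to the shared core yields a measurable value: the limit of > 23000 nM in this assay, at which 4 of the 4 values shown sit.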